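Isopropyl on the Carbamoyl Nitrogen: Compound 3 to Compound 4

The source may hold more compounds than are shown below. What is called first, only, known or untested is meant among the compounds shown, and "the series" means these compounds.

Measured in a functional assay on MGC-803 cells (Homo sapiens) for cytotoxicity, read by MTT assay, with a stated time of 72 h; on this read-out lower numbers stand for stronger inhibition and higher numbers for weaker inhibition:
Compound 1 `NC(=O)N1CCN(C(=S)SCc2cn(Cc3ccccc3F)nn2)CC1`: 11300 nM
Compound 2 `CCNC(=O)N1CCN(C(=S)SCc2cn(Cc3ccc(Cl)cc3)nn2)CC1`: 35400 nM
Compound 3 `COc1cc(Cn2cc(CSC(=S)N3CCN(C(N)=O)CC3)nn2)cc(OC)c1OC`: > 128000 nM, a limit of the assay rather than a number.

Compound 3 therefore stands at the weak end of what is shown, being the one compound sitting at the limit of > 128000 nM in this assay, at which 1 of the 3 values shown sits. Compound 1 and compound 2 give numbers, and the value of compound 2 is the higher of the two. Compound 4 `COc1cc(Cn2cc(CSC(=S)N3CCN(C(=O)NC(C)C)CC3)nn2)cc(OC)c1OC` differs from compound 3 only by isopropyl in place of hydrogen on an amide-type nitrogen. Going by the values given here, no measured pair isolates this change, since compound 1 and compound 2 differ from each other elsewhere as well. In this assay no shift beyond the scatter is expected. Compound 4 is estimated at 128000 nM, between 40000 nM and 300000 nM. The expected step from compound 3 to compound 4 is a number no higher from compound 3 to compound 4 (the limit leaves the size open), with a fair chance that only a limit is reported again.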

Compound 4, half-maximal inhibitory concentration: > 128000 nM
Compound 4: only a limit was reported (the forecaster's own chance of this, stated with the estimate: 55%); the middle value lies on the limit itself.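

No step can be read from compound 3 to compound 4, since each is reported only as a limit of the assay: the limit of > 128000 nM in this assay, at which 2 of the 4 values shown sit. The compounds shown leave open whether isopropyl in place of hydrogen on an amide-type nitrogen shifts the value at all.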